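Swapping the Acyl Group of the Amide in Compound 1

The source may report more compounds than this note shows. Statements on the series, on what has been measured and on what is new or still open speak of the compounds shown alone.

Compound 1: `C/C=C/C(=O)Nc1cccc(Cn2nc(-c3ccc(Oc4ccccc4)cc3)cc2CO)c1` — 22600 nM
Compound 2: `C/C=C/C(=O)Nc1cccc(Cn2nc(-c3ccc(Oc4ccccc4)cc3)cc2C(=O)OCC)c1` — 16700 nM

For the measured compounds named here, in a functional assay on JeKo-1 cells (Homo sapiens) for inhibition, read by luminescence and CellTiter-Glo, with a stated time of 72 h (on this read-out lower numbers stand for stronger inhibition and higher numbers for weaker inhibition), compound 1 stands highest of the two numbers; its only neighbour is compound 2, reached by a 1.4-fold lower number from compound 1 to compound 2 (0.13 log units; within the scatter). Compound 3 `O=C(CCl)Nc1cccc(Cn2nc(-c3ccc(Oc4ccccc4)cc3)cc2CO)c1` differs from compound 1 by chloromethyl in place of prop-1-en-1-yl on a carbonyl carbon. Going by the values given here, no measured step touches the acyl side of the amide, so nothing in the data bears directly on this change, and a step in either direction or none beyond the scatter is possible. Compound 3 is therefore estimated at 12000 nM, within 3000 nM to 45000 nM, meaning an expected 1.9-fold lower number from compound 1 to compound 3 (0.27 log units; within the scatter).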

Compound 3, half-maximal inhibitory concentration: 400 nM
Compound 3: the middle estimate sits 30-fold (1.48 log units) above what was measured, outside the stated range (below it).
By their numbers in this assay, from the lowest: compound 3; then compounds 2 and 1 (each within the scatter of the next).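

In this assay, the acyl side of the amide proves highly sensitive: chloromethyl in place of prop-1-en-1-yl on a carbonyl carbon gives a 57-fold lower number from compound 1 to compound 3 (1.75 log units; beyond the scatter). The one earlier step, made elsewhere on the molecule, stayed within the scatter, so this is the first change shown to move the number beyond it. Nothing at hand accounts for the size of this step.

The compounds shown do not tell whether the chlorine itself matters, as a methyl or bromomethyl group on that carbonyl carbon would. They also leave open whether the step holds with ethoxycarbonyl in place of hydroxymethyl.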